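The source may hold more compounds than are shown below. What is called first, only, known or untested is meant among the compounds shown, and "the series" means these compounds.

Measured so far:
- compound 1 `CN(C)CCCCN(C[C@H]1Cc2ncccc2CN1)[C@H]1CCCc2cccnc21`: 100%
- compound 2 `c1cnc2c(c1)CN[C@@H](CN(CCCCNC1CCOCC1)[C@H]1CCCc3cccnc31)C2`: 97%

For the measured compounds named here, in an ADME assay on microsomes from liver (Homo sapiens) for metabolic stability, using NADPH, with a stated time of 10 min (a lower number here means that less of the compound is left, a higher number that more of the compound is left), compound 2 gives 97%, within the scatter of compound 1, the only other number. Compound 3 `c1cnc2c(c1)CN[C@@H](CN(CCCCNC1COC1)[C@H]1CCCc3cccnc31)C2` is the next to be read, and it differs from compound 2 as follows: oxetan-3-yl in place of oxan-4-yl on an amine nitrogen. In short, this is oxetan-3-yl in place of oxan-4-yl on an amine nitrogen. Going by the values given here, no measured compound carries oxetan-3-yl. Among the compounds with values here, the one measured step that bears on the change is a number 3 percentage points lower from compound 1 to compound 2 (within the scatter), where (oxan-4-yl)amino replaced dimethylamino. That single small step is thin evidence, but it gives no reason to expect a shift beyond the scatter in this assay. The expected change is a number 2 percentage points lower from compound 2 to compound 3 (within the scatter). For compound 3 the estimated value is 95%, with an expected range of 82% to 100%.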

Compound 3, percent of the compound remaining: 97%
For compound 3 the middle estimate is 2 percentage points below the measured one, within the range that was stated.
By their numbers in this assay, from the lowest: compounds 2, 3 and 1 (each within the scatter of the next).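

In this assay, the change from a six-membered to a four-membered ring on this amine nitrogen gives no change at the digits printed from compound 2 to compound 3 (within the scatter). Measured against the dimethylamino end group, the oxetan-3-yl compound gives a number 3 percentage points lower from compound 1 to compound 3 (within the scatter), so at this position neither ring size separates from dimethylamino in this read-out. Nothing available explains this flat reading.

The compounds shown stay within the scatter of one another, so they do not reveal which change at this amine nitrogen, if any, would move the number in this assay. Open cases include piperidin-4-yl, with a ring nitrogen in place of the ring oxygen, and a longer chain between this amine nitrogen and the shared core.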